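The source may report more compounds than this note shows. Statements on the series, on what has been measured and on what is new or still open speak of the compounds shown alone.

Measured compounds in an assay (strain Wistar) for displacement of a labelled ligand from adenosine receptor A1 (Rattus norvegicus), read by scintillation counting; a lower number here means a stronger inhibitor, a higher number a weaker inhibitor:
compound 1, `CCOc1ccccc1C(=O)Nc1nc(-c2ccccc2)nc2c1nnn2Cc1ccccc1`: 1850 nM
compound 2, `COc1ccc(Cl)cc1C(=O)Nc1nc(-c2ccccc2)nc2c1nnn2Cc1ccccc1`: 7150 nM
compound 3, `Nc1nc(-c2ccccc2)nc2c1nnn2Cc1ccccc1`: 5.6 nM

Among these three numbers compound 1 stands second highest. Its nearest neighbour is compound 2, reached through a 3.9-fold higher number from compound 1 to compound 2 (0.59 log units; beyond the scatter), and its furthest is compound 3, reached through a 330-fold lower number from compound 1 to compound 3 (2.52 log units; beyond the scatter). The same contrast is seen in a 1300-fold lower number from compound 2 to compound 3 (3.11 log units; beyond the scatter): either acyl group on the ring nitrogen leaves the number far above that of the unacylated compound 3, whereas swapping one aryl group for the other on the carbonyl carbon moves it only modestly.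

Compound 4, `O=C(Nc1nc(-c2ccccc2)nc2c1nnn2Cc1ccccc1)c1cccc(F)c1`, is not yet measured. It differs from compound 1 in one place: 3-fluorophenyl in place of 2-ethoxyphenyl on a carbonyl carbon. Among the measured compounds shown here, the only measured step that bears on this is the modest one from compound 1 to compound 2, which also exchanged the aryl group on the carbonyl carbon. That step gives no ground to expect compound 4 to approach compound 3; at most a modest shift from compound 1, in either direction, or none beyond the scatter, is expected in this assay. Compound 4 is therefore expected to give about 2500 nM, within a range of 600 nM to 10000 nM. This estimate corresponds to the expected step of a 1.4-fold higher number from compound 1 to compound 4 (0.13 log units; within the scatter).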

Compound 4, inhibition constant: 22 nM
The estimate for compound 4 lay 110-fold (2.06 log units) above the measured number; measured number below the stated range.
By their numbers in this assay, from the lowest: compound 3; then compound 4; then compound 1; then compound 2.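

In this assay, the aryl group on the carbonyl carbon can carry a large change in the number and not only a modest one, as the exchange for 3-fluorophenyl shows (an 84-fold lower number from compound 1 to compound 4 (1.92 log units; beyond the scatter)) and as the comparison with the 5-chloro-2-methoxyphenyl amide confirms (a 330-fold lower number from compound 2 to compound 4 (2.51 log units; beyond the scatter)). An acyl group on the nitrogen therefore need not leave the number far above that of the unacylated compound: compound 4 stays only modestly apart from it (a 3.9-fold higher number from compound 3 to compound 4 (0.59 log units; beyond the scatter)), so the earlier contrast holds for the acyl groups of compound 1 and compound 2 but not for that of compound 4. Nothing available here accounts for the size of this change.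

The step from compound 1 to compound 4 removes the 2-ethoxyphenyl group and brings in the 3-fluorophenyl group in a single exchange, so the compounds shown cannot separate what goes with losing the ethoxy group from what goes with gaining the fluorine. Plain phenyl, 2-fluorophenyl or 3-chlorophenyl on the same carbonyl carbon would speak to this, and how far the number depends on the aryl ring at all remains open, as an acetyl group in its place would test.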